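The compounds below may be only part of what the source reports. "The series", "measured", "known", "first", "only" and "open" are said of these compounds alone.

The compounds share one core, seen in compound 1, `COc1cc(-c2nn(-c3cccc(NC(=O)Nc4cc(C(F)(F)F)cc(C(F)(F)F)c4)c3)cc2-c2ccncc2)ccc1Cl`, and differ only in the group carried on an amide-type nitrogen. In a functional assay on NCI-H460 cells (Homo sapiens) for inhibition, read by sulforhodamine B assay, with a stated time of 48 h (a lower number here means that less compound is tolerated, a higher number that more compound is tolerated), compound 1 gives 16300 nM. Compound 2, `COc1cc(-c2nn(-c3cccc(NC(=O)Nc4ccc(Cl)c(Cl)c4)c3)cc2-c2ccncc2)ccc1Cl`, carries a 3,4-dichlorophenyl group there. For compound 2 this assay reports only a limit, > 50000 nM, which is not a number but the edge of the measured range, the same edge noted in the limit of > 50000 nM in this assay, at which 1 of the 2 values shown sits. Compound 2 therefore has no exact place among the values shown; it stands at that limit while compound 1 stands at a read number.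

Compound 3, `COc1cc(-c2nn(-c3cccc(NC(=O)Nc4cccc(C(F)(F)F)c4)c3)cc2-c2ccncc2)ccc1Cl`, is reached from compound 2 by 3-(trifluoromethyl)phenyl in place of 3,4-dichlorophenyl on an amide-type nitrogen. Within the data shown here, no step between two measured compounds covers this change, so its size has to be guessed from the two values in hand, one a number and one a limit. Compound 3 is expected to land near 30000 nM, with a range from 10000 nM to 80000 nM. The step from compound 2 to compound 3 is accordingly expected to be an at least 1.6-fold lower number from compound 2 to compound 3 (0.22 log units; that floor lies within the scatter), though a second limit would not surprise.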

Compound 3, concentration lethal to 50% of the cells: > 50000 nM
Compound 3 was reported as a limit; the forecaster's own chance of this, stated with the estimate: 40%; at least 1.6-fold (0.22 log units) between middle value and limit.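

In this assay, among these compounds, hydrogen in place of one trifluoromethyl on an aromatic carbon of the group on the amide-type nitrogen gives an at least 3.0-fold higher number from compound 1 to compound 3 (0.48 log units; beyond the scatter), the only readable step so far at this position. The step between compound 2 and compound 3 cannot be read, as both values are limits, so 3-(trifluoromethyl)phenyl and 3,4-dichlorophenyl cannot be ordered against each other. Among the three groups shown, only the one in compound 1, which carries two trifluoromethyl groups, gives a read number, while the other two stand at the edge of the measured range: the limit of > 50000 nM in this assay, at which 2 of the 3 values shown sit.

As far as these compounds go, how far compound 2 and compound 3 lie past that limit remains open, and a single read number cannot show whether the second trifluoromethyl group is what matters or whether other groups would serve as well. From the compounds shown here alone, it is also open whether a nitrile or a carboxylic acid on the same aromatic ring, or a cyclohexyl group in place of the aromatic ring, would give a read number in this assay.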